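A few compounds are considered here, and "the series" means these few. Any claim that something is new, unique, unknown or untested is made for them only; others in the source may bear on it.

Compound 1, `O=C(/C=C1\CCc2ccc(F)cc21)NCC1CC1`, in a functional assay on the whole organism with Rattus norvegicus as the target, at a dose of 20 mg/kg by the oral route; a lower number here means less inhibition, a higher number more inhibition at the dose given (going by the name of the read-out): 21%
Compound 2, `O=C(/C=C1\CCc2c(F)cc(F)cc21)NC1CC1`: 28%

Compound 1 has the lower of the two numbers in this assay, yet compound 2 at 28% lies within the scatter of it, so neither can be ranked above the other. Compound 3, `O=C(/C=C1\CCc2ccc(F)cc21)NC1CCC1`, differs from compound 1 by cyclobutyl in place of cyclopropylmethyl on an amide-type nitrogen. Within the data shown here, no measured pair shows this change. The account therefore expects a step of a number 1 percentage points higher from compound 1 to compound 3 (within the scatter), no larger than the scatter and of no set direction. Compound 3 is estimated at 22%, in a range from 8% to 38%.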

Compound 3, a percentage reported as inhibition, in the whole organism at one dose (the size of the read-out at that dose, not a potency): 0%
Estimate against measurement, compound 3: 22 percentage points above, and the stated range ends above it.
By their numbers in this assay, from the lowest: compound 3; then compounds 1 and 2 (each within the scatter of the next).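

In this assay, the group on the amide-type nitrogen is not interchangeable: cyclobutyl in place of cyclopropylmethyl gives a number 21 percentage points lower from compound 1 to compound 3 (beyond the scatter). Both groups hold 4 carbon atoms and no hydrogen-bond donors or acceptors, so the two compounds have the same atoms, joined differently, and that alone separates them here. No measurement offered here accounts for the step. From the compounds shown here alone, whether cyclopentyl or a longer chain such as n-butyl on this nitrogen would sit with compound 1 or with compound 3 remains open. So does whether an amine in that group would keep any of the effect.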